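The source may report more compounds than this note shows. Statements on the series, on what has been measured and on what is new or still open speak of the compounds shown alone.

Working notes on the series in a functional assay on HL-60 cells (Homo sapiens) for cytotoxicity; on this read-out higher numbers stand for lower toxicity in this test and lower numbers for higher toxicity in this test.

The series holds two measured compounds and one pending. Compound 1 `COc1ccc(/C=C2\CCC/C(=C\c3ccc([N+](=O)[O-])cc3)C2=O)cc1` carries a cyclohexanone-derived core with a methoxyphenyl and a nitrophenyl arm. In this assay compound 1 gives only a limit, > 400000 nM, and no number. That value stands at the limit of > 400000 nM in this assay, at which 1 of the 2 values shown sits. Compound 2 `O=C1/C(=C/c2ccc(O)cc2)Cc2ccccc2/C1=C\c1ccc([N+](=O)[O-])cc1`, with a hydroxyphenyl and a nitrophenyl arm on a different core, gives in this assay 2500 nM. Among the compounds with values here, no step between compound 1 and compound 2 is computed, so the two values are only set side by side: compound 2 shows the single number, and compound 1 shows a limit.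

Compound 3 `COc1cc(/C=C2\Cc3ccccc3/C(=C\c3ccc([N+](=O)[O-])cc3)C2=O)ccc1O` is not yet measured. It differs from compound 2 by methoxy in place of hydrogen on an aromatic carbon. Within the data shown here, no step between measured compounds exists that shows what this change does in this assay, so the expectation rests on the numbers of compound 2 alone. The step from compound 2 to compound 3 is expected to be small, no change at the digits printed from compound 2 to compound 3 (within the scatter), within the usual scatter, with no clear direction. Compound 3 is therefore estimated to give 2500 nM in this assay, between 1000 nM and 6500 nM.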

Compound 3, half-maximal cytotoxic concentration: 950 nM
Beside the measured number, compound 3's estimate is 2.6-fold (0.42 log units) above it; the measured number lies below the stated range.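

The series now holds its first readable step: in this assay, methoxy in place of hydrogen on an aromatic carbon, ortho to a hydroxy group, gives a 2.6-fold lower number from compound 2 to compound 3 (0.42 log units; beyond the scatter) on the shared core. Within the data shown here, the change from 4-hydroxyphenyl to 4-hydroxy-3-methoxyphenyl thus moves the read-out toward higher toxicity in this test, a direction that the earlier compounds, joined by no one-place step, could not show. No measured property at hand bears on the cause of this step.

In this assay, among these compounds, compound 1 gives a limit and not a number, > 400000 nM, and no one-place step ties it to the other two compounds, so what separates its core from the shared core stays unresolved. Also open, on these data alone, is whether the step belongs to methoxy itself or would recur with ethoxy, a longer chain on the same oxygen, or with an amine at this place, and whether it would hold on an arm that lacks the hydroxy group.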